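A few compounds are considered here, and "the series" means these few. Any claim that something is new, unique, unknown or untested is made for them only; others in the source may bear on it.

Working notes on the series. In a functional assay on NCI-H460 cells (Homo sapiens) for inhibition, read by CCK-8 assay, with a stated time of 72 h, tested at 1 uM (a lower number here means less inhibition of growth, a higher number more inhibition of growth at the concentration tested), compound 1 (`CN(C)C(=O)c1cc2cnc(Nc3ccc(NC(=O)C4(C(=O)Nc5cccc(F)c5)CC4)cc3)nc2n1C1CCCC1`) gives 45.1%, the highest of the three measured numbers. Compound 2 (`Nc1ccc(NC(=O)C2(C(=O)Nc3ccc(F)cc3)CC2)cc1F`) gives 26.7% and compound 3 (`CN(C)C(=O)c1cc2cnc(Nc3ccc(NC(=O)C4(C(=O)Nc5ccc(F)cc5)CC4)cc3F)nc2n1C1CCCC1`) gives 11.9%, both beyond the scatter from compound 1. Among the compounds with values here, no two measured compounds differ in one place only, so no measured step isolates the next change.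

Compound 4 (`CN(C)C(=O)c1cc2cnc(Nc3ccc(NC(=O)C4(C(=O)Nc5ccc(O)cc5)CC4)cc3)nc2n1C1CCCC1`) carries 4-hydroxyphenyl in place of 3-fluorophenyl on an amide-type nitrogen. Within the data shown here, compound 1 at 45.1% tops the measured numbers, so a fall in this assay is the likelier direction, moderate in size and only modestly beyond the scatter, with a wide margin since the data hold no direct precedent. The expected step is a number 15.1 percentage points lower from compound 1 to compound 4 (beyond the scatter). In this assay the estimate for compound 4 is 30%, with an expected range of 10% to 52%.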

Compound 4, percent growth inhibition at one concentration: 90.4%
The estimate for compound 4 lay 60.4 percentage points below the measured number; the measured number lies above the stated range.
By their numbers in this assay, from the lowest: compound 3; then compound 2; then compound 1; then compound 4.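

Within the data shown here, on the amide-type nitrogen, 4-hydroxyphenyl in place of 3-fluorophenyl gives the first single-place step in this assay, a number 45.3 percentage points higher from compound 1 to compound 4 (beyond the scatter), so this position can strongly shift growth inhibition at the concentration tested. The entering group counts 1 hydrogen-bond donor and 1 hydrogen-bond acceptor, the leaving group 0 of each, but this single step cannot tie the shift to either feature. No measurement at hand gives a reason for the step.

The step changes the substituent and its ring position together, so 3-hydroxyphenyl and 4-fluorophenyl on the core of compound 1 would be needed to separate the two. Also open, going by these compounds, is whether 4-methoxyphenyl or 4-aminophenyl at this nitrogen would match compound 4 at 90.4%.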